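Swapping an Aryl Ether into a Bile Acid Receptor Ligand

The source may hold more compounds than are shown below. What is called first, only, known or untested is meant among the compounds shown, and "the series" means these compounds.

The series is followed in an assay on isolated protein for agonist activity at Bile acid receptor (Homo sapiens), read by AlphaScreen, with a stated time of 30 min; a higher number here means a larger maximal response, a lower number a smaller maximal response. Compound 1 `CCOc1cccc(-c2ccc([C@H]3S[C@@H](C)C(=O)Nc4c3c(C)nn4-c3ccccc3C)cc2)c1` gives 13% in this assay, the lowest of the three numbers recorded. Compound 2 `Cc1nn(-c2ccccc2Cl)c2c1C(c1ccc(Oc3ccccc3)cc1)SC(C)C(=O)N2` gives 57% and compound 3 `COc1ccccc1-n1nc(C)c2c1NC(=O)[C@H](C)S[C@@H]2c1ccc(Oc2ccccc2)cc1` gives 37%; both lie beyond the scatter above compound 1, compound 3 nearer and compound 2 furthest, though each differs from compound 1 in more than one place, so no single step can be read from them.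

Compound 4 `COc1cccc(Oc2ccc([C@H]3S[C@@H](C)C(=O)Nc4c3c(C)nn4-c3ccccc3C)cc2)c1` has not yet been measured. It differs from compound 1 in one place, on an aromatic carbon para to a large group: 3-methoxyphenoxy in place of 3-ethoxyphenyl on an aromatic carbon. Among the compounds with values here, no measured pair separated by exactly this change is available, so the size of the step must be estimated from the spread of the three numbers alone. Given that compound 1 sits at 13% while compounds 2 and 3 reach higher, a modest rise beyond the scatter is expected, a number 17 percentage points higher from compound 1 to compound 4 (beyond the scatter). Compound 4 is therefore expected to give about 30% in this assay, in a range from 12% to 50%.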

Compound 4, largest response reached (reported as efficacy), in percent of the reference or control that the assay uses: 120%
For compound 4 the middle estimate is 90 percentage points below the measured one, outside the stated range (above it).
By their numbers in this assay, from the lowest: compound 1; then compound 3; then compound 2; then compound 4.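

At this place, on an aromatic carbon para to a large group, the swap of 3-ethoxyphenyl for 3-methoxyphenoxy is far from neutral: in this assay it gives a number 107 percentage points higher from compound 1 to compound 4 (beyond the scatter), the largest response of the series. The two groups match in heavy-atom count, at 9, and each holds one six-membered aromatic ring of carbon only, yet the entering group has 2 oxygen atoms and 2 hydrogen-bond acceptors in place of 1 of each, so maximal response at this place is highly sensitive to a change that leaves the size of the group unchanged. Nothing available gives a cause for this step.

The effect of the oxygen link cannot be separated from that of methoxy replacing ethoxy, and the 3-ethoxyphenoxy and 3-methoxyphenyl groups would be needed to divide the step. On these data alone, how an amine or a carboxylic acid in place of the methoxy group would fare also stays open.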